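Cyclic peroxide acids: inverting two ring stereocentres

The source may hold more compounds than are shown below. What is called first, only, known or untested is meant among the compounds shown, and "the series" means these compounds.

Measured compounds:
compound 1 `CC(=O)CC/C=C(\C)CCC1=C(C)CCCC1(C)C` gives > 15000 nM
compound 2 `COC(=O)[C@H](C)[C@H]1CC[C@@](C)(CCC2=C(C)CCCC2(C)C)OO1` gives > 25000 nM
compound 3 `C=C1CCCC(C)(C)C1CC[C@@]1(C)CC[C@H]([C@@H](C)C(=O)O)OO1` gives 5440 nM

Of the compounds shown here, three have been tested in a functional assay on SF-295 cells (Homo sapiens) for inhibition; on this read-out higher numbers stand for weaker inhibition of growth and lower numbers for stronger inhibition of growth. For compound 1 the result is a limit of this assay, > 15000 nM, and not a number; it is the limit described as the limit of > 15000 nM in this assay, at which 1 of the 3 values shown sits. For compound 2 the result is likewise a limit, > 25000 nM, the one described as the limit of > 25000 nM in this assay, at which 1 of the 3 values shown sits. For the measured compounds named here, compound 3 is therefore the only compound that gives a number in this assay, with 5440 nM. No ordering among the three can be drawn beyond that.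

Compound 4 `C=C1CCCC(C)(C)C1CC[C@]1(C)CC[C@@H]([C@@H](C)C(=O)O)OO1` has not yet been measured in this assay. It differs from compound 3 as follows: the two compounds have the same atoms and bonds; at least one stereo element is drawn with a configuration in one of them and without one in the other: 2 of 4 stereo elements differ; a stereocentre at a saturated ring carbon is drawn S in compound 3 and R in compound 4; a stereocentre at a saturated ring carbon is drawn R in compound 3 and S in compound 4. Two stereocentres in the peroxide-containing ring are thus inverted while every atom and bond stays the same.

Going by the values given here, no pair of measured compounds differing in a single place is available, so there is no measured step to lean on. Two inverted ring stereocentres can move a value in either direction, and the outcome is open. The expected step from compound 3 to compound 4 is a 1.5-fold higher number from compound 3 to compound 4 (0.17 log units; within the scatter), a modest drift toward weaker growth inhibition with wide uncertainty. Compound 4 is expected to give about 8000 nM in this assay, estimated to lie between 2500 nM and 25000 nM.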

Compound 4, concentration for 50% growth inhibition: > 10000 nM
Compound 4: only a limit was reported; the forecaster's own chance of this, stated with the estimate: 25%; at least 1.2-fold (0.09 log units) between middle value and limit.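

In this assay compound 4 gives > 10000 nM, which is a limit of the assay and not a number. Inverting the two stereocentres at saturated ring carbons while every atom and bond stays the same gives an at least 1.8-fold higher number from compound 3 to compound 4 (0.26 log units; that floor lies within the scatter); this is the first step among the compounds shown that can be read at all, and it speaks to the ring stereocentres alone, yet its floor does not settle whether the change in configuration matters beyond the usual scatter of this read-out. The pair also carries a reservation about how the two structures are drawn: the fact that one of compounds 3 and 4 is drawn with a defined configuration and the other without, at the place where they differ

Going by these compounds, what stays open is how far the true value of compound 4 lies from that of compound 3, and whether one of the two inverted stereocentres or both together account for the step. Also open, on these data alone, is how either configuration would behave in this assay with an amide or a primary alcohol in place of the carboxylic acid on the same core.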